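This account rests on a few compounds, and the source may have more. Where it says the series, first, only, none or still open, it means among the compounds named here.

Measured compounds:
compound 1 `FC(F)(F)c1ccc(CSc2nc(Nc3ccccc3Cl)c3ccccc3n2)cc1` — 20400 nM
compound 2 `COc1ccccc1Nc1nc(SCc2ccc(C(F)(F)F)cc2)nc2ccccc12` — 14100 nM
compound 3 `Cc1ccc(Nc2nc(SCc3ccc(C(F)(F)F)cc3)nc3ccccc23)cc1` — 21100 nM

All three numbers in a functional assay on PC-3 cells (Homo sapiens) for cytotoxicity, read by MTT assay, with a stated time of 72 h (on this read-out lower numbers stand for stronger inhibition and higher numbers for weaker inhibition), lie within the scatter of one another: a 1.4-fold lower number from compound 1 to compound 2 (0.16 log units; within the scatter), a 1.5-fold higher number from compound 2 to compound 3 (0.18 log units; within the scatter) and a 1.0-fold higher number from compound 1 to compound 3 (0.01 log units; within the scatter). Compound 2 therefore stands nowhere apart from compound 1 or compound 3.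

Compound 4 `COc1cc(Nc2nc(SCc3ccc(C(F)(F)F)cc3)nc3ccccc23)cc(OC)c1` is not yet measured. Its change from compound 2 is 3,5-dimethoxyphenyl in place of 2-methoxyphenyl on a nitrogen on an aromatic ring. Within the data shown here, the steps that bear on it are those that swapped the group on this nitrogen: a 1.5-fold higher number from compound 2 to compound 3 (0.18 log units; within the scatter) and a 1.0-fold higher number from compound 1 to compound 3 (0.01 log units; within the scatter), both within the scatter. Among the measured compounds shown here, no step in this set has moved the number beyond the scatter, so no step beyond it is expected here.

Compound 4 is expected at 16000 nM, range 8000 nM to 35000 nM, meaning an expected step of a 1.1-fold higher number from compound 2 to compound 4 (0.05 log units; within the scatter).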

Compound 4, half-maximal inhibitory concentration: > 50000 nM
Compound 4 was reported as a limit (the forecaster's own chance of this, stated with the estimate: 10%); at least 3.1-fold (0.49 log units) between middle value and limit.
By their numbers in this assay, from the lowest: compounds 2, 1 and 3 (each within the scatter of the next). At a limit, above all of these: compound 4.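

In this assay compound 4 gives > 50000 nM, which is a limit and not a number. The group on this nitrogen can therefore move the read-out beyond the scatter: an at least 3.5-fold higher number from compound 2 to compound 4 (0.54 log units; beyond the scatter), an at least 2.3-fold higher number from compound 3 to compound 4 (0.37 log units; beyond the scatter) and an at least 2.4-fold higher number from compound 1 to compound 4 (0.38 log units; beyond the scatter). The 2-chlorophenyl, 2-methoxyphenyl and 4-methylphenyl groups stay within the scatter of one another, so only 3,5-dimethoxyphenyl separates from the set, and the size of that separation is bounded only by a limit: the limit of > 50000 nM in this assay, at which 1 of the 4 values shown sits.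

On these data alone, how far compound 4 really lies from the others stays open. So does how an amine, a carboxylic acid or a hydroxy group on this phenyl ring would read.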